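A few compounds are considered here, and "the series" means these few. Any claim that something is new, unique, unknown or untested is made for them only; others in the source may bear on it.

Compound 1 `COc1cc(-n2cnc3ccc(-c4cccc(C)c4C)cc32)cc(OC)c1OC`: 2150 nM
Compound 2 `COc1ccc(-c2ccc3ncn(-c4cc(OC)c(OC)c(OC)c4)c3c2)cc1F`: 520 nM
Compound 3 `COc1cc(-n2cnc3ccc(-c4ccc(C)cc4)cc32)cc(OC)c1OC`: 110 nM

Three compounds share one core and differ only in the aryl group on it, measured in a functional assay on MCF7 cells (Homo sapiens) for antiproliferative activity, read by MTT assay, with a stated time of 72 h; a lower number here means a stronger inhibitor, a higher number a weaker inhibitor. Compound 3 stands lowest of the three: a 4.7-fold lower number from compound 2 to compound 3 (0.67 log units; beyond the scatter) and a 20-fold lower number from compound 1 to compound 3 (1.29 log units; beyond the scatter), both beyond the scatter. Compound 4 `COc1cc(-n2cnc3ccc(-c4cccc(Cl)c4)cc32)cc(OC)c1OC` carries 3-chlorophenyl in place of 4-methylphenyl on an aromatic carbon. Going by the values given here, no measured step bears directly on this change; the steps of a 4.1-fold lower number from compound 1 to compound 2 (0.62 log units; beyond the scatter) and a 4.7-fold lower number from compound 2 to compound 3 (0.67 log units; beyond the scatter) show only that moving away from 4-methylphenyl has so far raised the number by modest to large amounts. A modest rise is therefore expected, a 3.2-fold higher number from compound 3 to compound 4 (0.50 log units; beyond the scatter). Compound 4 is estimated at 350 nM, within a range from 100 nM to 1200 nM.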

Compound 4, half-maximal inhibitory concentration: 3120 nM
Beside the measured number, compound 4's estimate is 8.9-fold (0.95 log units) below it; the whole stated range lies below it.
By their numbers in this assay, from the lowest: compound 3; then compound 2; then compounds 1 and 4 (each within the scatter of the next).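

In this assay, 3-chlorophenyl in place of 4-methylphenyl gives a 28-fold higher number from compound 3 to compound 4 (1.45 log units; beyond the scatter), so this position separates two aryl groups sharply even though their heavy-atom counts match. It also gives a 6.0-fold higher number from compound 2 to compound 4 (0.78 log units; beyond the scatter), while a 1.5-fold higher number from compound 1 to compound 4 (0.16 log units; within the scatter) leaves 3-chlorophenyl unseparated from 2,3-dimethylphenyl, and both of these groups stand apart from 4-methylphenyl and 3-fluoro-4-methoxyphenyl. Nothing available here explains this difference. Open, going by these compounds, is whether the chlorine or its place governs the result, which 4-chlorophenyl and 3-methylphenyl would separate. On these data alone, how an amine on this aryl ring would behave also remains open.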